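The source may hold more compounds than are shown below. What is called first, only, known or untested is meant among the compounds shown, and "the series" means these compounds.

Going by the values given here, compound 2 `Nc1nc2c(c(=O)n(CC3CC3)c(=O)n2CC2CC2)n1S(=O)(=O)c1ccccc1` gives 13% in an assay on isolated protein with dual specificity calcium/calmodulin-dependent 3',5'-cyclic nucleotide phosphodiesterase 1B (Bos taurus) as the target, tested at 100 uM (on this read-out lower numbers stand for less inhibition and higher numbers for more inhibition at the one concentration tested (going by the name of the read-out)), the lowest of the two numbers so far; compound 1 `COc1ccc(Cn2c(N)nc3c2c(=O)n(CC2CC2)c(=O)n3CC2CC2)cc1` gives 60%, and the step of a number 47 percentage points lower from compound 1 to compound 2 (beyond the scatter) is the only measured one. Compound 3 `Nc1nc2c(c(=O)n(CC3CC3)c(=O)n2CC2CC2)n1S(=O)(=O)c1ccc(Cl)cc1` differs from compound 2 by chloro in place of hydrogen on an aromatic carbon. Among the compounds with values here, no measured step alters a substituent on the phenylsulfonyl ring, so the single step, a swap of the whole group on the aromatic nitrogen, bears only loosely on this change. For compound 3 a step within the scatter is therefore expected, a number 5 percentage points higher from compound 2 to compound 3 (within the scatter). Compound 3 is estimated at 18%, between 5% and 40%.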

Compound 3, a percentage reported as inhibition, at one concentration (the size of the read-out at that concentration, not a potency): 1%
Compound 3: middle estimate off by 17 percentage points, on the high side; the measured number lies below the stated range.
By their numbers in this assay, from the lowest: compound 3; then compound 2; then compound 1.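

The ring of the phenylsulfonyl group is a position that responds in this assay: chloro in place of hydrogen, para to a large group, gives a number 12 percentage points lower from compound 2 to compound 3 (beyond the scatter). With the (4-chlorophenyl)sulfonyl group in place of 4-methoxybenzyl on the aromatic nitrogen, the change is a number 59 percentage points lower from compound 1 to compound 3 (beyond the scatter). Nothing available explains the direction of the chloro step.

Open, going by these compounds, is whether a methoxy group or an amine at this same place on the ring would move the number the same way as chloro, and whether chloro elsewhere on the ring would do so.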